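Adding a Third Methoxy Group to Compound 3

The compounds below may be only part of what the source reports. "The series", "measured", "known", "first", "only" and "open" are said of these compounds alone.

Compound 1 `Cc1cc(O)c(C2=NN(c3ccc(S(N)(=O)=O)cc3)C(c3ccccc3O)C2)cc1Cl`, compound 2 `Cc1cc(O)c(C2=NN(c3ccc(S(N)(=O)=O)cc3)C(c3ccccc3Cl)C2)cc1Cl` and compound 3 `COc1ccc(C2CC(c3cc(Cl)c(C)cc3O)=NN2c2ccc(S(N)(=O)=O)cc2)cc1OC` share one core and differ only in the aryl group attached to a saturated ring carbon. In a functional assay on U-251 cells (Homo sapiens) for antiproliferative activity, with a stated time of 48 h (a lower number here means a stronger inhibitor of growth, a higher number a weaker inhibitor of growth), compound 1 gives 7760 nM, compound 2 gives 5020 nM and compound 3 gives 14000 nM, the highest of the three numbers. The step of a 1.8-fold higher number from compound 1 to compound 3 (0.26 log units; within the scatter) stays within the scatter, while a 2.8-fold higher number from compound 2 to compound 3 (0.45 log units; beyond the scatter) is modest. Compound 4 `COc1ccc(C2CC(c3cc(Cl)c(C)cc3O)=NN2c2ccc(S(N)(=O)=O)cc2)c(OC)c1OC` differs from compound 3 by methoxy in place of hydrogen on an aromatic carbon. Within the data shown here, none of the measured steps adds a single methoxy group to an otherwise unchanged aryl ring; each swaps the whole aryl group, so they offer little guidance here. The step of no change at the digits printed from compound 3 to compound 4 (within the scatter) is therefore expected to stay within the scatter. Compound 4 is estimated to give 14000 nM, with a range from 6000 nM to 35000 nM.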

Compound 4, concentration for total growth inhibition: 8890 nM
Beside the measured number, compound 4's estimate is 1.6-fold (0.20 log units) above it; measured number inside the range.
By their numbers in this assay, from the lowest: compounds 2, 1, 4 and 3 (each within the scatter of the next, the first and the last beyond it).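

The first direct test of adding one methoxy group to an otherwise unchanged aryl ring, in this assay, gives a 1.6-fold lower number from compound 3 to compound 4 (0.20 log units; within the scatter), so this aromatic carbon takes the group with no shift beyond the scatter. Swapping the whole aryl group also gives small steps, with a 1.8-fold higher number from compound 2 to compound 4 (0.25 log units; within the scatter) and a 1.1-fold higher number from compound 1 to compound 4 (0.06 log units; within the scatter), although compound 3 stood beyond the scatter from compound 2. Nothing measured here explains these numbers.

Going by these compounds, whether an amine or a carboxylic acid on this same carbon would behave alike remains open.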